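A few compounds are considered here, and "the series" means these few. Any claim that something is new, unique, unknown or untested is made for them only; others in the source may bear on it.

Compound 1 `Fc1ccc(Nc2cc3[nH]c(-c4cccc(C(F)(F)F)c4)nc3cn2)nc1` is the starting point here. In a physicochemical assay for solubility, using the shake flask method, in simulated intestinal fluid, measured as kinetic solubility, with a stated time of 20 h, at pH 6.5 (a higher number here means a more soluble compound, a lower number a less soluble compound), compound 1 gives >= 50000 nM, which is a limit of the assay rather than a measured number. Compound 2 `Fc1ccc(Nc2cc3[nH]c(-c4ccc(F)c(C(F)(F)F)c4)nc3cn2)nc1` differs from compound 1 only by a fluoro in place of hydrogen on an aromatic carbon; compound 2 gives >= 50000 nM, again a limit. Because both sit at the limit of >= 50000 nM in this assay, at which 2 of the 3 values shown sit, the step that the two limits leave unreadable from compound 1 to compound 2 cannot be read. Compound 3 `FC(F)(F)c1cccc(-c2nc3cnc(Nc4cc(-c5nnn[nH]5)ccn4)cc3[nH]2)c1` carries a 1H-tetrazol-5-yl on its pyridine ring; compound 3 gives < 5000 nM, a limit at the low end of this assay, as noted at the limit of < 5000 nM in this assay, at which 1 of the 3 values shown sits.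

The change to compound 4 `FC(F)(F)c1cccc(-c2nc3cnc(Nc4ccc(-c5nnn[nH]5)cn4)cc3[nH]2)c1` is 1H-tetrazol-5-yl in place of fluoro on an aromatic carbon. Among the measured compounds shown here, no measured step covers this exact change, and the only readable step, from compound 1 to compound 2, is itself hidden by the limits. What the data do show is that compound 3, which also carries a 1H-tetrazol-5-yl, gives < 5000 nM in this assay.

On that basis compound 4 is expected to fall to roughly 3000 nM, within a range from 500 nM to 20000 nM. The estimated step of an at least 16-fold lower number from compound 1 to compound 4 (1.22 log units; beyond the scatter) is therefore expected to be a marked drop in solubility, likely reported only as a limit.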

Compound 4, solubility: < 5000 nM
Compound 4 was reported as a limit; the forecaster's own chance of this, stated with the estimate: 60%; the middle value lies beyond the limit too.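

Putting 1H-tetrazol-5-yl in place of fluoro on an aromatic carbon, two atoms from the ring nitrogen and para to a large group, gives an at least 10-fold lower number from compound 1 to compound 4 (1.00 log units; beyond the scatter), whereas the earlier step between two compounds that differ in one place could not be read. In this assay compound 4 gives < 5000 nM, which is a limit and not a number, so the step is a minimum rather than an exact size. Compound 4 therefore joins compound 3 at the low end of the scale, and the upper and lower ends of the scale are now equally filled: the limit of < 5000 nM in this assay, at which 2 of the 4 values shown sit.

The compounds shown leave open how far the true value of compound 4 lies beyond its limit, and so how large the full step is. They also leave open whether the drop follows from the five-membered ring itself or would appear with any group at this place, which a carboxylic acid or an amine on the same carbon could help to separate.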